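The source may hold more compounds than are shown below. What is called first, only, known or untested is meant among the compounds shown, and "the series" means these compounds.

Compound 1 `COc1ccc(S(C)(=O)=O)c(NCC2=NCCN2)c1` and compound 2 `COc1ccc(SC)c(NCC2=NCCN2)c1` are the two measured compounds. In a functional assay for agonist activity at Alpha-1D adrenergic receptor (Homo sapiens) (on this read-out lower numbers stand for an effect already at smaller amounts and higher numbers for an effect only at larger amounts of compound), compound 1 gives < 100000 nM, which is a limit of the assay and not a number. In this assay compound 2 gives 5.01 nM. The step that the limit leaves unreadable from compound 1 to compound 2 has no readable size because the limit of < 100000 nM in this assay, at which 1 of the 2 values shown sits, is where compound 1 sits.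

Compound 3 `CS(=O)(=O)c1ccc(C(F)(F)F)cc1NCC1=NCCN1` differs from compound 1 by trifluoromethyl in place of methoxy on an aromatic carbon, while the methylsulfonyl group of compound 1 is kept. For the measured compounds named here, no measured step touches the methoxy position; the single measured step, from compound 1 to compound 2, changes the methylsulfonyl group instead and is itself unreadable. Compound 1 stands only at a limit, so the starting point is itself uncertain. The expected step that the limit leaves unreadable from compound 1 to compound 3 is therefore an estimate with wide uncertainty in both directions. Compound 3 is estimated at 3000 nM, with a range from 100 nM to 100000 nM.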

Compound 3, half-maximal effective concentration: < 100000 nM
Compound 3: only a limit was reported (the forecaster's own chance of this, stated with the estimate: 30%); the middle value is on the limit's open side.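

No step can be read from compound 1 to compound 3, since each of the two compounds stands only at a limit of the assay: the limit of < 100000 nM in this assay, at which 2 of the 3 values shown sit.

The compounds shown leave open whether trifluoromethyl in place of methoxy changes the result in this assay at all.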